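The source may hold more compounds than are shown below. What is called first, only, known or untested is meant among the compounds shown, and "the series" means these compounds.

Notes on the series. Compound 1 `Cc1cc(=O)oc2cc(SCc3cccnc3)ccc12` is read in a functional assay on DU-145 cells (Homo sapiens) for antiproliferative activity, read by sulforhodamine B assay, with a stated time of 72 h (on this read-out higher numbers stand for weaker inhibition of growth and lower numbers for stronger inhibition of growth), only as a limit, giving > 35200 nM and no number. Compound 2 `Cc1cc(=O)oc2cc(SCc3cccc(C#N)c3)ccc12` likewise returns only a limit, > 32500 nM in this assay. Going by the values given here, compound 1 thus stands at a limit (the limit of > 35200 nM in this assay, at which 1 of the 2 values shown sits), and the one further value shown also sits at a limit (the limit of > 32500 nM in this assay, at which 1 of the 2 values shown sits). Compound 3 `Cc1cccc(CSc2ccc3c(C)cc(=O)oc3c2)c1` carries 3-methylphenyl in place of pyridin-3-yl on a saturated chain carbon bound to a sulfur. Among the compounds with values here, no measured step between compounds is at hand, so the expected step that the limit leaves unreadable from compound 1 to compound 3 is none beyond the scatter. Compound 3 is therefore expected to give 40000 nM, with a range of 15000 nM to 100000 nM.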

Compound 3, concentration for 50% growth inhibition: > 33700 nM
Compound 3: a limit, no number; the forecaster's own chance of this, stated with the estimate: 70%; the middle value does not contradict the limit.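

Compound 3 gives only a limit in this assay, > 33700 nM. No step can be read from compound 1 or compound 2 to compound 3, as all three values are limits. The compounds shown leave open whether any substituent on this shared core changes growth inhibition.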